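The source may hold more compounds than are shown below. What is called first, only, known or untested is meant among the compounds shown, and "the series" means these compounds.

Compound 1 `COc1cccc(/C=C/C(=O)c2ccc(OC)c3c2OC(C)(C)C=C3)c1` is one of three close relatives that share a core and differ only in the aryl group on the double-bonded chain. In a functional assay on HepG2 cells (Homo sapiens) for antiproliferative activity, read by MTT assay, with a stated time of 24 h (a higher number here means a weaker inhibitor, a lower number a stronger inhibitor), compound 1 gives > 10000 nM, which is a limit of the assay rather than a measured number. Compound 2 `COc1ccc(C(=O)/C=C/c2cc(OC)c(OC)c(OC)c2)c2c1C=CC(C)(C)O2` shows the same picture: in this assay compound 2 gives > 10000 nM, again a limit. Compound 3 `COc1ccc(C(=O)/C=C/c2ccc(N(c3ccccc3)c3ccccc3)cc2)c2c1C=CC(C)(C)O2` follows suit, as in this assay compound 3 gives > 10000 nM, also a limit. So compound 1 stands where every value shown stands, at the limit of > 10000 nM in this assay, at which 3 of the 3 values shown sit, and no ordering among the three can be read from these numbers.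

Compound 4 `COc1ccc(C(=O)/C=C/c2ccccn2)c2c1C=CC(C)(C)O2` has not yet been measured. It differs from compound 1 by pyridin-2-yl in place of 3-methoxyphenyl on a double-bonded chain carbon bound to a double-bonded chain carbon. Because every relative so far sits at the limit of > 10000 nM in this assay, at which 3 of the 3 values shown sit, no step beyond the usual scatter is expected in this assay; the step from compound 1 to compound 4 is estimated as a step that the limit leaves unreadable from compound 1 to compound 4. Compound 4 is expected to give about 15000 nM, with a likely range from 5000 nM to 50000 nM.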

Compound 4, half-maximal inhibitory concentration: 5760 nM
The estimate for compound 4 lay 2.6-fold (0.42 log units) above the measured number; measured number inside the range.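

In this assay, the change at this place gives an at least 1.7-fold lower number from compound 1 to compound 4 (0.23 log units; that floor lies within the scatter). Going by these compounds alone, compound 4 is the first compound with a measured number rather than a limit, which shows that the group on this double-bonded chain carbon can bring the shared core within the range the assay can read, although the floor of the step stays within the scatter. The full size of the step cannot be read because the value of compound 1 is a limit: the limit of > 10000 nM in this assay, at which 3 of the 4 values shown sit.

From the compounds shown here alone, it remains open whether the ring nitrogen of pyridin-2-yl goes with the change, as a plain phenyl at this place would be needed to separate it from the loss of the methoxy group. Going by these compounds, it is equally open whether other rings holding nitrogen, such as an imidazole, would give a measured number here.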